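A Methyl on the Aromatic Oxygen of Compound 2

This account rests on a few compounds, and the source may have more. Where it says the series, first, only, none or still open, it means among the compounds named here.

Going by the values given here, in a functional assay on IMR-32 cells (Homo sapiens) for inhibition, with a stated time of 48 h, tested at 50 uM (on this read-out higher numbers stand for more inhibition of growth at the one concentration tested and lower numbers for less inhibition of growth), compound 2 `CC(C)=CCCC(C)(/C=C/c1ccc(O)cc1)/C=C/c1ccc(O)cc1` gives 30%, the higher of the two numbers so far, while compound 1 `COc1ccc(/C=C/[C@@](C)(/C=C/c2ccc(O)cc2)CCC=C(C)C)cc1` gives 6%. Compound 3 `COc1ccc(/C=C/[C@](C)(/C=C/c2ccc(O)cc2)CCC=C(C)C)cc1` departs from compound 2 by methyl in place of hydrogen on an oxygen on an aromatic ring. Among the compounds with values here, the one measured step bearing on this is the opposite change, hydrogen in place of methyl, a modest a number 24 percentage points higher from compound 1 to compound 2 (beyond the scatter). A fall of similar size is therefore expected in this assay, an estimated a number 22 percentage points lower from compound 2 to compound 3 (beyond the scatter). The expected value for compound 3 is 8%, within an estimated range of 0% to 20%.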

Compound 3, percent growth inhibition at one concentration: 69%
Beside the measured number, compound 3's estimate is 61 percentage points below it, outside the stated range (above it).
By their numbers in this assay, from the lowest: compound 1; then compound 2; then compound 3.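

In this assay, methyl in place of hydrogen on an oxygen on an aromatic ring does not act in one direction: it gives a number 39 percentage points higher from compound 2 to compound 3 (beyond the scatter), whereas compound 1 carries the same methyl and stands lower than compound 2. The configuration at the saturated chain carbon decides the outcome, with a number 63 percentage points higher from compound 1 to compound 3 (beyond the scatter). Nothing else separates these two methyl compounds: the fact that compounds 1 and 3 differ only in the configuration as drawn

Still open, going by these compounds, is whether a longer chain on that oxygen, or an amine in its place, would follow compound 3 or compound 1 in each configuration.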